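The source may hold more compounds than are shown below. What is called first, only, known or untested is meant among the compounds shown, and "the series" means these compounds.

Series notes.

Compound 1 `COc1cc(/C=C/C(=O)/C=C/c2cccs2)ccc1OCc1cn(CCOc2cc(=O)oc3ccccc23)nn1` gives 76%.
Compound 2 `COc1cc(/C=C/C(=O)/C=C/c2cc(OC)c(OC)c(OC)c2)ccc1OCc1cn(CCOc2cc(=O)oc3ccccc23)nn1` gives 99%.
Compound 3 `COc1cc(/C=C/C(=O)/C=C/c2cc(OC)c(OC)c(OC)c2)ccc1OCc1cn(CCCCOc2cc(=O)oc3ccccc23)nn1` gives 65%.

In a functional assay on THP-1 cells (Homo sapiens) for inhibition, read by sulforhodamine B assay, with a stated time of 48 h, tested at 50 uM (on this read-out lower numbers stand for less inhibition of growth and higher numbers for more inhibition of growth at the one concentration tested), the change thiophen-2-yl in place of 3,4,5-trimethoxyphenyl on a double-bonded chain carbon bound to a double-bonded chain carbon produced the step of a number 23 percentage points lower from compound 2 to compound 1 (beyond the scatter), a drop beyond the scatter. How the core of compound 3 differs from that of compound 2 is not broken down here; compound 3 stands lowest of the three measured values, beyond the scatter from both others.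

Compound 4 `COc1cc(/C=C/C(=O)/C=C/c2cccs2)ccc1OCc1cn(CCCCOc2cc(=O)oc3ccccc23)nn1` is not yet measured. It differs from compound 3 by thiophen-2-yl in place of 3,4,5-trimethoxyphenyl on a double-bonded chain carbon bound to a double-bonded chain carbon, the same change, at the same place, as from compound 2 to compound 1. For compound 4 a step of a number 23 percentage points lower from compound 3 to compound 4 (beyond the scatter) is expected, resting on the earlier step of a number 23 percentage points lower from compound 2 to compound 1 (beyond the scatter), with the reservation that compound 2 sits near the top of the scale, so the earlier drop may understate what the change does from a lower starting point. Compound 4 is thus estimated at 42%, with a likely range of 22% to 62%.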

Compound 4, percent growth inhibition at one concentration: 44%
Compound 4: middle estimate off by 2 percentage points, on the low side; measured number inside the range.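

In this assay, thiophen-2-yl in place of 3,4,5-trimethoxyphenyl on a double-bonded chain carbon bound to a double-bonded chain carbon gives a number 21 percentage points lower from compound 3 to compound 4 (beyond the scatter), and this step agrees with the earlier one: the same change on two cores in this assay, a number 23 percentage points lower (beyond the scatter) from compound 2 to compound 1 and a number 21 percentage points lower (beyond the scatter) from compound 3 to compound 4, 2 percentage points apart, within the scatter of two such steps
The change therefore carries over between the core of compound 2 and the core of compound 3 with a step of about the same size. Among the compounds shown here, this rests on only two pairs tested at one concentration, so it does not establish that the step holds on other cores, and it gives no reason for the drop.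

The compounds shown leave open whether other groups at this place, such as an unsubstituted phenyl or a pyridine ring, would give a similar number. Going by these compounds, it also remains open whether the step would hold on a core with a longer chain than that of compound 3.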